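Trifluoromethyl replaces trifluoromethoxy on compound 3's outer ring

A few compounds are considered here, and "the series" means these few. Any claim that something is new, unique, unknown or untested is made for them only; others in the source may bear on it.

The series is built on a shared core, carrying a biaryl arm that varies at its far end. Compound 1 `Cc1n[nH]c(C(=O)O)c1Cc1cccc(-c2ccc(C#N)cc2)c1` gives 300 nM in an assay on isolated protein for inhibition of 2-Hydroxyacid oxidase 2 (Rattus norvegicus); a higher number here means a weaker inhibitor, a lower number a stronger inhibitor. Going by the values given here, compound 2 `Cc1n[nH]c(C(=O)O)c1Cc1cccc(-c2ccccc2F)c1` gives 900 nM in this assay, and the one step within the set, a 3.0-fold higher number from compound 1 to compound 2 (0.48 log units; beyond the scatter), shows a modest weakening. Compound 3 `Cc1n[nH]c(C(=O)O)c1Cc1ccc(-c2ccc(OC(F)(F)F)cc2)cc1` gives 2000 nM in this assay, the highest number of the three measured; compound 2 sits nearest to it and compound 1 furthest.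

Compound 4 `Cc1n[nH]c(C(=O)O)c1Cc1ccc(-c2ccc(C(F)(F)F)cc2)cc1` differs from compound 3 by trifluoromethyl in place of trifluoromethoxy on an aromatic carbon. Among the compounds with values here, the only measured step, from compound 1 to compound 2, concerns a different exchange on the biaryl arm and so does not speak to this change directly; no measured pair shows what trifluoromethyl against trifluoromethoxy does here. With no guidance beyond that, little movement beyond the scatter is expected, and compound 4 is expected to show a step of a 1.3-fold lower number from compound 3 to compound 4 (0.12 log units; within the scatter) in this assay. Compound 4 is therefore estimated at 1500 nM, with a range from 500 nM to 4500 nM.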

Compound 4, half-maximal inhibitory concentration: 1100 nM
The estimate for compound 4 lay 1.4-fold (0.13 log units) above the measured number, within the range that was stated.
By their numbers in this assay, from the lowest: compound 1; then compounds 2, 4 and 3 (each within the scatter of the next, the first and the last beyond it).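

Trifluoromethyl in place of trifluoromethoxy, on an aromatic carbon para to a large group, gives a 1.8-fold lower number from compound 3 to compound 4 (0.26 log units; within the scatter) in this assay, so removing the oxygen at this place produces no change that can be told from the scatter. Going by these compounds alone, the earlier step concerned other groups, which makes this pair the first reading of this exchange, and as a single pair it speaks only for the arm that compound 3 and compound 4 share. Nothing available bears on the origin of this result.

From the compounds shown here alone, whether an amine, a carboxylic acid or a longer chain such as butoxy at this place would move the number beyond the scatter remains open. Also open, going by these compounds, is whether the same exchange would read alike on the arm as it stands in compound 1.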